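The source may hold more compounds than are shown below. What is called first, only, known or untested is meant among the compounds shown, and "the series" means these compounds.

Working notes on the series. The shared core of compound 1 `CCn1c(C(=O)NCCCN(C)C)ccc1C(CC)(CC)c1ccc(OCC(=O)C(C)(C)C)c(C)c1` carries an amide on one side and an aryl ether on the other. Among the compounds with values here, in a functional assay on Caco-2 cells (Homo sapiens), read by MTT assay, with a stated time of 48 h (a higher number here means a weaker inhibitor, a lower number a stronger inhibitor), compound 1 gives 1400 nM, the lowest of the two numbers so far; its nearest neighbour is compound 2 `CCn1c(C(=O)NCCCN(C)C)ccc1C(CC)(CC)c1ccc(OCC(O)C(C)(C)C)c(C)c1`, which in this assay gives 1900 nM, so that a 1.4-fold higher number from compound 1 to compound 2 (0.13 log units; within the scatter). Compound 3 `CCn1c(C(=O)N(C)CC(=O)O)ccc1C(CC)(CC)c1ccc(OCC(=O)C(C)(C)C)c(C)c1` has not yet been measured in this assay. It differs from compound 1 by (carboxymethyl)(methyl)amino in place of (3-(dimethylamino)propyl)amino on a carbonyl carbon. Within the data shown here, no measured step touches this part of the molecule: the only step seen so far, from compound 1 to compound 2, sits on the saturated chain carbon bound to the aromatic oxygen and stayed within the scatter, so it gives no guidance for the carbonyl side. For compound 3 the expected change is a 1.8-fold higher number from compound 1 to compound 3 (0.25 log units; within the scatter), with a wide range to reflect the absence of a comparable step. The estimate for compound 3 in this assay is 2500 nM, between 700 nM and 9000 nM.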

Compound 3, half-maximal inhibitory concentration: 35900 nM
Compound 3: middle estimate off by 14-fold (1.16 log units), on the low side; measured number outside the range, above it.
By their numbers in this assay, from the lowest: compounds 1 and 2 (each within the scatter of the next); then compound 3.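

In this assay, the substituent on the carbonyl carbon matters far more than the earlier comparison could suggest: (carboxymethyl)(methyl)amino in place of (3-(dimethylamino)propyl)amino gives a 26-fold higher number from compound 1 to compound 3 (1.41 log units; beyond the scatter). This large step contrasts with the change on the saturated chain carbon, a 1.4-fold higher number from compound 1 to compound 2 (0.13 log units; within the scatter), so this position is the first in the series shown to respond strongly to a change. Nothing available explains the size of this step.

The exchange alters the dimethylamino end, the chain and the amide hydrogen together, so the compounds shown do not separate the contribution of each. Going by these compounds, it also remains open how a plain propyl chain, a methylated amide keeping the dimethylamino end, or a carboxylic acid on a longer chain would read here.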